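Extending a Phenol Ether on a Shared Imide Core

The source may report more compounds than this note shows. Statements on the series, on what has been measured and on what is new or still open speak of the compounds shown alone.

Compound 1 `Cc1ccc(S(=O)(=O)NCCCCN2C(=O)C(c3ccc(F)cc3)=C(c3ccc(OCC(=O)NCC(=O)NCC(=O)O)cc3)C2=O)cc1` and compound 2 `O=C1C(c2ccc(O)cc2)=C(c2ccc(F)cc2)C(=O)N1CCC(O)(c1ccccc1)c1ccccc1` were both tested in an ADME assay on RAW264.7 cells (Mus musculus) for cytotoxicity, read by MTT assay, with a stated time of 48 h; a lower number here means that less compound is tolerated, a higher number that more compound is tolerated. For compound 1 the assay reported only the limit > 100000 nM. Compound 2 likewise gave only the limit > 100000 nM. Both values therefore sit at the limit, as described by the limit of > 100000 nM in this assay, at which 2 of the 2 values shown sit. Compound 3 `CCN(CC)CCCOc1ccc(C2=C(c3ccc(F)cc3)C(=O)N(CCC(O)(c3ccccc3)c3ccccc3)C2=O)cc1` differs from compound 2 by 3-(diethylamino)propyl in place of hydrogen on an oxygen on an aromatic ring. Going by the values given here, with no measured step to guide it, the expected move from compound 2 to compound 3 is an at least 1.4-fold lower number from compound 2 to compound 3 (0.15 log units; that floor lies within the scatter), a shift not clearly beyond the usual scatter and tending toward less tolerance. Compound 3 is accordingly estimated at 70000 nM, between 25000 nM and 200000 nM.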

Compound 3, concentration lethal to 50% of the cells: 37600 nM
For compound 3 the middle estimate is 1.9-fold (0.27 log units) above the measured one, and the stated range covers the measured number.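

In this assay, placing 3-(diethylamino)propyl on the oxygen in place of hydrogen gives an at least 2.6-fold lower number from compound 2 to compound 3 (0.42 log units; beyond the scatter), the first difference in this set that can be read at all. Going by these compounds alone, this shows that a change at this oxygen can move the read-out beyond the scatter, whereas the earlier compounds showed only limits. Only a floor can be given for the step because compound 2 rests at a limit: the limit of > 100000 nM in this assay, at which 2 of the 3 values shown sit.

Going by these compounds, what stays open is whether the amine or the chain carries this step. A plain alkyl ether without an amine, or a longer chain ending in a piperidine, would separate the two.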